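Replacing the Acylsulfonamide of Compound 2 with a Carboxylic Acid

The compounds below may be only part of what the source reports. "The series", "measured", "known", "first", "only" and "open" are said of these compounds alone.

Compounds measured so far:
- compound 2, `O=C(CCCOc1ccc(OCc2ccc3ccccc3n2)cc1)NS(=O)(=O)c1ccccc1`: 31 nM
- compound 1, `c1ccc2nc(COc3ccc(OCCCc4nnn[nH]4)cc3)ccc2c1`: 69 nM

Both compounds were tested in an assay on isolated protein for binding affinity to cysteinyl leukotriene receptor 1 (Cavia porcellus); on this read-out lower numbers stand for stronger inhibition and higher numbers for weaker inhibition. Compound 2 stands at the lowest of the two numbers, so it is the stronger binder here; compound 1 gives a higher number, and the gap between the two lies beyond the usual scatter of repeated measurements, so this order can be trusted.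

Compound 3, `O=C(O)CCCOc1ccc(OCc2ccc3ccccc3n2)cc1`, has not yet been measured. It differs from compound 2 in a single place: hydroxy in place of (phenylsulfonyl)amino on a carbonyl carbon. Both the group that leaves and the one that enters carry a hydrogen-bond donor, but the leaving group is much larger. Going by the values given here, no pair of measured compounds shows this particular exchange, so there is no measured step to lean on. The expectation is that compound 3 binds somewhat more weakly than compound 2, with a step of a 3.2-fold higher number from compound 2 to compound 3 (0.51 log units; beyond the scatter) that is modest but beyond the scatter. The estimated value for compound 3 in this assay is 100 nM, within a range from 30 nM to 350 nM.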

Compound 3, inhibition constant: 1200 nM
For compound 3 the middle estimate is 12-fold (1.08 log units) below the measured one; measured number outside the range, above it.
By their numbers in this assay, from the lowest: compound 2; then compound 1; then compound 3.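

Exchanging the (phenylsulfonyl)amino group on the carbonyl carbon for hydroxy costs a great deal of binding in this assay, with a 39-fold higher number from compound 2 to compound 3 (1.59 log units; beyond the scatter), even though both groups carry a hydrogen-bond donor, so having a donor in this place is clearly not enough to keep the binding of compound 2. Exchanging 1H-tetrazol-5-yl for carboxy at the end of the same saturated chain also gives a large loss, with a 17-fold higher number from compound 1 to compound 3 (1.24 log units; beyond the scatter), so the carboxylic acid falls well behind both of the other chain ends, and the two earlier compounds alone gave no sign of how far binding could drop here. Nothing available here explains either loss.

The compounds shown leave open whether the gain of compound 2 over compound 3 needs the whole phenyl ring of the (phenylsulfonyl)amino group, a question that a methylsulfonylamino group or a simple primary amide on the same carbonyl carbon would address. They also leave open whether a longer chain could recover any of the binding lost by the carboxylic acid of compound 3.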